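A few compounds are considered here, and "the series" means these few. Any claim that something is new, unique, unknown or untested is made for them only; others in the source may bear on it.

Compound 3 `Cc1ccc(NC(=O)NC(=O)c2ccc(OCc3ccc(Cl)c(Cl)c3)cc2)cc1-c1nc2ccccc2[nH]1` carries a (3,4-dichlorobenzyl)oxy group on its aromatic ring. Among the compounds with values here, in a functional assay on HT-29 cells (Homo sapiens) for inhibition, read by MTT assay, with a stated time of 48 h (on this read-out higher numbers stand for weaker inhibition and lower numbers for stronger inhibition), compound 3 gives 1030 nM, the second highest of the three numbers measured so far. Its nearest neighbour is compound 1 `Cc1ccc(NC(=O)NC(=O)c2ccc(OCc3ccccc3F)cc2)cc1-c1nc2ccccc2[nH]1`, which in this assay gives 760 nM; the gap a 1.4-fold higher number from compound 1 to compound 3 (0.13 log units; within the scatter) lies within the scatter. Far from both is compound 2 `Cc1ccc(NC(=O)NC(=O)c2ccc(OCc3cccc(F)c3)cc2)cc1-c1nc2ccccc2[nH]1`, which in this assay gives 38200 nM; the step of a 37-fold lower number from compound 2 to compound 3 (1.57 log units; beyond the scatter) is large, as is the step of a 50-fold higher number from compound 1 to compound 2 (1.70 log units; beyond the scatter).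

Compound 4 `Cc1ccc(NC(=O)NC(=O)c2ccc(OCc3ccc(Cl)cc3Cl)cc2)cc1-c1nc2ccccc2[nH]1` has not yet been measured. It differs from compound 3 by 2,4-dichlorophenyl in place of 3,4-dichlorophenyl on a saturated chain carbon bound to an oxygen on an aromatic ring. Within the data shown here, no measured step rearranges two chlorines in this way, so the guide is indirect: the 2-fluorophenyl of compound 1 and the 3,4-dichlorophenyl of compound 3 both give low numbers, and only the 3-fluorophenyl of compound 2 stands far off. The 2,4-dichlorophenyl of compound 4 shares part of its name with each of the two low-numbered groups, so for compound 4 the expected step is a 1.3-fold lower number from compound 3 to compound 4 (0.11 log units; within the scatter), within the scatter. For compound 4 the estimate in this assay is 800 nM, with a range from 250 nM to 3000 nM.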

Compound 4, half-maximal inhibitory concentration: 2620 nM
The estimate for compound 4 lay 3.3-fold (0.52 log units) below the measured number; the measured number falls inside the stated range.
By their numbers in this assay, from the lowest: compounds 1 and 3 (each within the scatter of the next); then compound 4; then compound 2.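

In this assay, putting 2,4-dichlorophenyl in place of 3,4-dichlorophenyl gives a 2.5-fold higher number from compound 3 to compound 4 (0.41 log units; beyond the scatter) and shows that two groups with the same atoms, joined differently, are not interchangeable at this position. Compound 4 is also set apart from the 2-fluorophenyl group by a 3.4-fold higher number from compound 1 to compound 4 (0.54 log units; beyond the scatter) and from the 3-fluorophenyl group by a 15-fold lower number from compound 2 to compound 4 (1.16 log units; beyond the scatter) so it sits between the low numbers and the far-off one, and sharing part of a name with a low-numbered group does not settle the result. Nothing available explains how the arrangement of the chlorines changes the number.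

Still open, going by these compounds, is whether the change in number follows the chlorines alone or would recur with other groups on the phenyl ring. A methoxy group or an amine in place of the chlorines could test that.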